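This account rests on a few compounds, and the source may have more. Where it says the series, first, only, none or still open, it means among the compounds named here.

Compound 1 `NC1=NC2(CCSCC2)N(OCCCOc2cccc(Cl)c2)C(N)=N1`: 260 nM
Compound 2 `Cc1ccc(OCCCON2C(N)=NC(N)=NC23CCOCC3)cc1`: 2580 nM
Compound 3 `Cc1cc(C)cc(OCCCON2C(N)=NC(N)=NC23CCOCC3)c1`: 720 nM

Of the compounds shown here, three have been measured in a functional assay on HL-60 cells (Homo sapiens) for antiproliferative activity, read by MTT assay, with a stated time of 72 h; a higher number here means a weaker inhibitor, a lower number a stronger inhibitor. Compound 1 `NC1=NC2(CCSCC2)N(OCCCOc2cccc(Cl)c2)C(N)=N1` gives 260 nM, the lowest number of the three; compound 3 `Cc1cc(C)cc(OCCCON2C(N)=NC(N)=NC23CCOCC3)c1` gives 720 nM and compound 2 `Cc1ccc(OCCCON2C(N)=NC(N)=NC23CCOCC3)cc1` gives 2580 nM, so compound 1 stands apart from both beyond the scatter. Within the data shown here, the single measured step, a 3.6-fold lower number from compound 2 to compound 3 (0.55 log units; beyond the scatter), is the only change on the aryl ring that has been followed, and it lowers the number modestly.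

Compound 4 `NC1=NC2(CCSCC2)N(OCCCOc2ccc(Cl)c(Cl)c2)C(N)=N1` differs from compound 1 by chloro in place of hydrogen on an aromatic carbon. Among the measured compounds shown here, no measured pair shows this exact change. The step from compound 2 to compound 3 is the nearest guide: a second small substituent on the aryl ring brought a modest gain there, but with a different group and on a different core, so it transfers only loosely. A small step to a lower number, or none beyond the scatter, is therefore expected in this assay, a 1.4-fold lower number from compound 1 to compound 4 (0.16 log units; within the scatter). Compound 4 is estimated at 180 nM, between 70 nM and 500 nM.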

Compound 4, half-maximal inhibitory concentration: 140 nM
For compound 4 the middle estimate is 1.3-fold (0.11 log units) above the measured one; measured number inside the range.
By their numbers in this assay, from the lowest: compounds 4 and 1 (each within the scatter of the next); then compound 3; then compound 2.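

In this assay chloro in place of hydrogen on an aromatic carbon, ortho to a chloro group and para to a large group, turns 3-chlorophenyl into 3,4-dichlorophenyl and gives a 1.9-fold lower number from compound 1 to compound 4 (0.27 log units; within the scatter). Among these compounds, this is the first step followed on the aryl ring of the core of compound 1, and it shows that this place takes a second chloro group with no difference that can be told from the scatter. No measurement shown here accounts for the size of this step.

From the compounds shown here alone, whether a methoxy group, a nitrile or an amine at this same place would stay within the scatter remains open. So does whether chloro here would give a similar step on the core of compound 2.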